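Swapping Chloro for Cyano in a Solubility Series

The compounds below may be only part of what the source reports. "The series", "measured", "known", "first", "only" and "open" are said of these compounds alone.

- compound 1 `Cc1nn(-c2ccccc2)c2nc(-c3ccc(C(C)C)cc3)c(C#N)c(-c3ccccc3O)c12`: 9800 nM
- compound 2 `Cc1nn(-c2ccccc2)c2nc(-c3ccc4ccccc4c3)c(C#N)c(-c3ccccc3O)c12`: 1800 nM
- compound 3 `Cc1nn(-c2ccccc2)c2nc(-c3ccc(Cl)cc3)c(C#N)c(-c3ccccc3O)c12`: 3800 nM

All three values come from a physicochemical assay for solubility, read by spectrophotometry, in phosphate buffer, with a stated time of 18 h, at pH 7.4; a lower number here means a less soluble compound, a higher number a more soluble compound. Compound 3, at 3800 nM, is the second highest of the three numbers, with compound 1 above it and compound 2 below it.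

The next compound, compound 4 `Cc1nn(-c2ccccc2)c2nc(-c3ccc(C#N)cc3)c(C#N)c(-c3ccccc3O)c12`, has not yet been measured. It carries cyano in place of chloro on an aromatic carbon, para to a large group, so 4-chlorophenyl becomes 4-cyanophenyl.

Three measured steps change this same group on the shared core. The closest is the change of isopropyl to chloro, a 2.6-fold lower number from compound 1 to compound 3 (0.41 log units; beyond the scatter). The replacement of naphthalen-2-yl by 4-chlorophenyl gives a 2.1-fold higher number from compound 2 to compound 3 (0.32 log units; beyond the scatter), and the widest of the three is a 5.4-fold lower number from compound 1 to compound 2 (0.74 log units; beyond the scatter). All three are modest, though each lies beyond the scatter. None of them involves cyano, so the data do not fix a direction.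

A step no larger than these is therefore expected in this assay, and possibly none beyond the scatter. The expected change is a 1.2-fold higher number from compound 3 to compound 4 (0.07 log units; within the scatter). The estimate for compound 4 is 4500 nM, with an expected range of 1800 nM to 11000 nM.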

Compound 4, solubility: 1700 nM
Beside the measured number, compound 4's estimate is 2.6-fold (0.42 log units) above it; measured number outside the range, below it.
By their numbers in this assay, from the lowest: compounds 4 and 2 (each within the scatter of the next); then compound 3; then compound 1.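

Placing cyano on this aromatic carbon, para to a large group, gives a 2.2-fold lower number from compound 3 to compound 4 (0.35 log units; beyond the scatter) in this assay and shows that this position still responds to a change between two small groups, a change that also adds a hydrogen-bond acceptor. Compound 4 and compound 2 cannot be told apart, with a 1.1-fold lower number from compound 2 to compound 4 (0.02 log units; within the scatter) lying within the scatter, so 4-cyanophenyl and naphthalen-2-yl give matching results here even though they differ in size and ring count. The isopropyl compound remains highest of the four, with a 5.8-fold lower number from compound 1 to compound 4 (0.76 log units; beyond the scatter) as the widest step in the series, but no measurement at hand accounts for the ranking of these groups.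

The compounds shown leave open how an amine, a carboxylic acid or a methoxy group would behave at this same place on the phenyl ring. They also leave open whether replacing chloro with cyano would give a similar step on a core carrying a different group elsewhere, since all four compounds share the same remaining structure.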